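The source may report more compounds than this note shows. Statements on the series, on what has been measured and on what is new or still open speak of the compounds shown alone.

In a functional assay on U-937 cells (Homo sapiens) for cytotoxicity, read by MTT assay, with a stated time of 72 h (on this read-out lower numbers stand for stronger inhibition and higher numbers for weaker inhibition), compound 3 `Cc1c(C)c2c(c(C)c1O)CCC(C)(C(=O)NC1CC(C)(C)N([O])C1(C)C)O2` gives 98000 nM. This is within the usual scatter of compound 1 `Cc1c(C)c2c(c(C)c1OC(=O)CCC(=O)O)CCC(C)(C(=O)NC1CC(C)(C)N([O])C(C)(C)C1)O2`, which gives 123000 nM, whereas compound 2 `Cc1c(C)c2c(c(C)c1OC(=O)CCC(=O)O)CCC(C)(C(=O)NCC1CC(C)(C)N([O])C1(C)C)O2` gives a clearly lower 24000 nM. Compound 4 `Cc1c(C)c2c(c(C)c1OC(=O)CCC(=O)O)CCC(C)(C(=O)NC1CC(C)(C)N([O])C1(C)C)O2` differs from compound 3 in one place: (2-carboxyethyl)carbonyl in place of hydrogen on an oxygen on an aromatic ring. The hydroxy thus becomes ((2-carboxyethyl)carbonyl)oxy, and the group on the amide nitrogen stays the same.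

For the measured compounds named here, no measured pair shows this exchange on its own. Going by the values given here, the only measured step, a 5.1-fold lower number from compound 1 to compound 2 (0.71 log units; beyond the scatter), swaps a six-membered for a five-membered ring group while the (2-carboxyethyl)carbonyl stays in place. Compound 4 carries that same (2-carboxyethyl)carbonyl and also a five-membered ring, though its ring group is not identical to that of compound 2. In this assay, a modest move towards a lower number is therefore expected, close to the edge of the scatter and uncertain in size. The expected change is a 2.0-fold lower number from compound 3 to compound 4 (0.29 log units; within the scatter). For compound 4, the estimated value is 50000 nM, with an expected range of 18000 nM to 120000 nM.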

Compound 4, half-maximal inhibitory concentration: 163000 nM
Compound 4: middle estimate off by 3.3-fold (0.51 log units), on the low side, outside the stated range (above it).
By their numbers in this assay, from the lowest: compound 2; then compounds 3, 1 and 4 (each within the scatter of the next).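

On this position, in this assay replacing hydroxy with ((2-carboxyethyl)carbonyl)oxy stays within the scatter (a 1.7-fold higher number from compound 3 to compound 4 (0.22 log units; within the scatter)), so the exchange shows no clear effect when the group on the amide nitrogen is held constant. With (2-carboxyethyl)carbonyl kept, the group on the amide nitrogen separates the compounds only in one case: the pair with compound 2 lies beyond the scatter (a 6.8-fold higher number from compound 2 to compound 4 (0.83 log units; beyond the scatter)), while the pair with compound 1 stays within it (a 1.3-fold higher number from compound 1 to compound 4 (0.12 log units; within the scatter)). A five-membered ring alone therefore does not bring the lower number of compound 2, and no measured evidence at hand explains this.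

Still open, as far as these compounds go, is whether an acetyl group, a longer chain or an amine-bearing chain on this oxygen would behave differently. Also open, from the compounds shown here alone, is whether the hydroxy form carrying the amide group of compound 2 would keep that lower number.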